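The source may hold more compounds than are shown below. What is called first, only, known or untested is meant among the compounds shown, and "the series" means these compounds.

Compound 1, with the structure `O=S(=O)(/C=C/c1ccc(Cl)cc1Cl)Cc1ccc(Nc2ncnc3ccccc23)cc1`, is the reference point. In a functional assay on SK-OV-3 cells (Homo sapiens) (on this read-out higher numbers stand for weaker inhibition of growth and lower numbers for stronger inhibition of growth), compound 1 gives 2000 nM. Compound 2, with the structure `O=S(=O)(/C=C/c1ccc(F)cc1Cl)Cc1ccc(Nc2ncnc3ccccc23)cc1`, differs from it by a single change: fluoro in place of chloro on an aromatic carbon. That change produced a 22-fold higher number from compound 1 to compound 2 (1.34 log units; beyond the scatter), so in this assay compound 2 gives 44000 nM.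

Compound 3, with the structure `O=S(=O)(/C=C/c1ccc(F)cc1Cl)Cc1ccc(Nc2ncnc3cc(Cl)ccc23)cc1`, carries a further change on the shared core, an at least 2.2-fold higher number from compound 2 to compound 3 (0.35 log units; beyond the scatter). For compound 3 this assay reports only a limit, > 100000 nM, which is the limit of > 100000 nM in this assay, at which 1 of the 3 values shown sits. How the core of compound 3 differs from that of compound 1 is not broken down here.

Compound 4, with the structure `O=S(=O)(/C=C/c1ccc(F)cc1F)Cc1ccc(Nc2ncnc3cc(Cl)ccc23)cc1`, is not yet measured. It differs from compound 3 by fluoro in place of chloro on an aromatic carbon. Among the measured compounds shown here, this is the same kind of change as the one from compound 1 to compound 2, but the surroundings differ: there the fluoro entered meta to a chloro group and para to a large group, here it enters ortho to a large group and meta to a fluoro group. The earlier instance moved the number upward by a large amount, and compound 3 already sits at a limit, so compound 4 is expected to stay at or beyond that limit, with an estimated step that the limit leaves unreadable from compound 3 to compound 4. The expected value for compound 4 is 300000 nM, within a range from 80000 nM to 2000000 nM.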

Compound 4, concentration for 50% growth inhibition: > 100000 nM
Compound 4 ended at the assay's limit (the forecaster's own chance of this, stated with the estimate: 85%); the middle value lies beyond the limit too.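

No step can be read from compound 3 to compound 4, because both stand at a limit of this assay and not at a number: the limit of > 100000 nM in this assay, at which 2 of the 4 values shown sit.

The compounds shown leave open whether going from 2-chloro-4-fluorophenyl to 2,4-difluorophenyl changes growth inhibition at all on a core with this added chloro, and how far beyond the limit either compound lies.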